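Replacing a Benzyl Group on a Shared Amide Core

The source may hold more compounds than are shown below. What is called first, only, known or untested is meant among the compounds shown, and "the series" means these compounds.

Compound 1, `CC(=O)c1cccc(NC(=O)C2CCCN(C(=O)c3cc(C(F)(F)F)cc(C(F)(F)F)c3)C2)c1`, was examined in an ADME assay on PC-3 cells (Homo sapiens) for cytotoxicity, read by WST assay, tested at 100 uM (a lower number here means less inhibition, a higher number more inhibition at the concentration tested (going by the name of the read-out)), where compound 1 gives 0%. Compound 2, `O=C(Nc1cccc(Cc2ccccc2)c1)C1CCCN(C(=O)c2cc(C(F)(F)F)cc(C(F)(F)F)c2)C1`, carries a benzyl in place of the acetyl and gives 0% in this assay. The step of no change at the digits printed from compound 1 to compound 2 (within the scatter) shows that this exchange on an aromatic carbon left the read-out unchanged within the scatter, so compound 2 stands level with compound 1 on the numbers at hand. Compound 3, `COC(=O)c1cc(-c2cccc(NC(=O)C3CCCN(C(=O)c4cc(C(F)(F)F)cc(C(F)(F)F)c4)C3)c2)co1`, has not yet been measured. It differs from compound 2 as follows: 5-(methoxycarbonyl)furan-3-yl in place of benzyl on an aromatic carbon. For the measured compounds named here, the only measured step, from compound 1 to compound 2, concerned the same aromatic carbon and was flat. Nothing measured points to a change at this position, so no step beyond the scatter is expected for compound 3 when a 5-(methoxycarbonyl)furan-3-yl replaces the benzyl. The expected value for compound 3 in this assay is 0%, within a range from -10% to 15%. This estimate corresponds to an expected step of no change at the digits printed from compound 2 to compound 3 (within the scatter).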

Compound 3, a percentage reported as inhibition, at one concentration (the size of the read-out at that concentration, not a potency): 0%
Compound 3: the middle estimate sits on the measured number at the digits printed; low and high end bracket the measured number.
By their numbers in this assay, from the lowest: compounds 1, 2 and 3 (each within the scatter of the next).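

In this assay, the exchange of benzyl for 5-(methoxycarbonyl)furan-3-yl gives no change at the digits printed from compound 2 to compound 3 (within the scatter), and the exchange of acetyl for the same group gives no change at the digits printed from compound 1 to compound 3 (within the scatter). This position, on an aromatic carbon of a six-membered aromatic ring of carbon only and meta to a large group, has therefore now carried three different groups with a flat read-out, and the flat result extends to a five-membered aromatic ring with 1 hetero atom and to a group with 3 hydrogen-bond acceptors where benzyl has 0. Nothing available accounts for this flat read-out.

The compounds shown leave open whether an amine or a carboxylic acid at this position would give a step beyond the scatter, and whether exchanging a trifluoromethyl group elsewhere on the shared core would do so. They also leave open whether any difference among these three compounds would appear at another concentration, since the read-out here comes from a single one.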